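The source may report more compounds than this note shows. Statements on the series, on what has been measured and on what is new or still open speak of the compounds shown alone.

Measured so far:
compound 1 `COc1ccc(F)cc1N1C(=O)CSC1c1cccc(C(=O)NCCCCc2ccccc2)c1` — 62%
compound 2 `CCN1C(=O)CSC1c1cccc(C(=O)NCCCCc2ccccc2)c1` — 40%

In a functional assay on 143B cells (Homo sapiens) for inhibition, read by CCK-8 assay, with a stated time of 72 h, tested at 1 uM (on this read-out lower numbers stand for less inhibition and higher numbers for more inhibition at the one concentration tested (going by the name of the read-out)), compound 2 gives the lowest of the two numbers; its nearest neighbour is compound 1, which lies higher by a margin beyond the scatter. Within the data shown here, the only step in hand, a number 22 percentage points lower from compound 1 to compound 2 (beyond the scatter), shows that a ring group on the amide-type nitrogen in the ring is worth more than ethyl there. Compound 3 `COc1ccc(N2C(=O)CSC2c2cccc(C(=O)NCCCCc3ccccc3)c2)c(OC)c1` differs from compound 2 by 2,4-dimethoxyphenyl in place of ethyl on an amide-type nitrogen in a ring. That change runs opposite to the measured step, so a rise of a modest size is expected. Compound 3 is expected to give about 58%, with a range from 40% to 75%. The expected step is therefore a number 18 percentage points higher from compound 2 to compound 3 (beyond the scatter).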

Compound 3, a percentage reported as inhibition, at one concentration (the size of the read-out at that concentration, not a potency): 53%
Compound 3: middle estimate off by 5 percentage points, on the high side, within the range that was stated.
By their numbers in this assay, from the lowest: compound 2; then compounds 3 and 1 (each within the scatter of the next).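

In this assay, among these compounds, the change to 2,4-dimethoxyphenyl from ethyl on the amide-type nitrogen in the ring gives a number 13 percentage points higher from compound 2 to compound 3 (beyond the scatter), so the advantage over ethyl is no longer tied to the single ring group in compound 1. Exchanging one substituted phenyl for the other gives a number 9 percentage points lower from compound 1 to compound 3 (within the scatter), and these two ring groups cannot be told apart in this assay here. No evidence bears on the reason for either step.

Still open, as far as these compounds go, is whether the ring alone accounts for the rise or its methoxy groups contribute. Unsubstituted phenyl or a longer chain such as butyl on this nitrogen would help separate these readings.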